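The compounds below may be only part of what the source reports. "The series", "measured", "known", "first", "only" and "open" are said of these compounds alone.

Working notes on the series. Going by the values given here, in an ADME assay on MDBK cells (Bos taurus) for cytotoxicity, read by MTT assay, with a stated time of 96 h (on this read-out lower numbers stand for higher toxicity in this test and higher numbers for lower toxicity in this test), compound 2 `CN(C)CCCNc1ccc(/N=N/c2ccccc2)cc1` gives 58000 nM, the only true number so far. Compound 1 `Cc1ccc(/N=N/c2ccc(NCCCN(C)C)cc2)cc1` reads > 100000 nM, which is a limit of the assay and not a number. Compound 3 `Brc1cccc(/N=N/N2CCCCC2)c1` reads > 100000 nM, also a limit. The series therefore shows (the limit of > 100000 nM in this assay, at which 2 of the 3 values shown sit), and compound 2 cannot be ranked firmly against either neighbour.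

Next is compound 4 `CN(C)CCCNc1ccc(/N=N/c2ccc([N+](=O)[O-])cc2)cc1`, with nitro in place of hydrogen on an aromatic carbon, para to a large group: nitro in place of hydrogen on an aromatic carbon. Among the compounds with values here, one measured step bears on this, also a change on an aromatic carbon: an at least 1.7-fold lower number from compound 1 to compound 2 (0.23 log units; that floor lies within the scatter). That is a floor, and it involves a different group, so it gives only weak guidance on size and none on direction for nitro. No step beyond the scatter is therefore expected in this assay, though the uncertainty is wide. The expected change is a 1.3-fold lower number from compound 2 to compound 4 (0.11 log units; within the scatter). For compound 4 the estimated value is 45000 nM, with an expected range from 14000 nM to 100000 nM.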

Compound 4, half-maximal cytotoxic concentration: > 100000 nM
Compound 4 gave a limit, no number (the forecaster's own chance of this, stated with the estimate: 25%); at least 2.2-fold (0.34 log units) between middle value and limit.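

In this assay, nitro in place of hydrogen on an aromatic carbon, para to a large group, gives an at least 1.7-fold higher number from compound 2 to compound 4 (0.23 log units; that floor lies within the scatter); this is a floor and not a measured size. Going by these compounds alone, with the earlier compounds, methyl was the only group at this position to be compared with hydrogen, and nitro now gives the same kind of result, so compound 2, with hydrogen there, remains the only one of these three with a true number. The change from methyl to nitro cannot be read, because compound 1 and compound 4 both sit at the same limit: the limit of > 100000 nM in this assay, at which 3 of the 4 values shown sit.

From the compounds shown here alone, how far compound 4 lies past that limit remains open. Also open, going by these compounds, is whether an amine or a carboxylic acid at this position would give a true number in this assay.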